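Replacing phenyl with butyl in a pair of inhibitors

The source may report more compounds than this note shows. Statements on the series, on what has been measured and on what is new or still open speak of the compounds shown alone.

In a functional assay on a cell-free system (plasma, Homo sapiens), with a stated time of 3 min (a higher number here means a weaker inhibitor, a lower number a stronger inhibitor), compound 1 (`O=C(NCc1cc(Cl)ccc1-n1cnnn1)[C@@H]1CC=NN1C(=O)[C@H](O)Cc1ccccc1`) gives 1400 nM, and compound 2 (`O=C(NCc1cc(Cl)ccc1-n1cnnn1)[C@@H]1C[C@H]2C[C@H]2N1C(=O)[C@H](O)c1ccccc1`) gives 680 nM. Compound 2 therefore holds the lower of the two numbers and is the stronger inhibitor of the pair, with a gap to compound 1 that lies beyond the scatter.

The next compound to be considered is compound 3 (`CCCC[C@@H](O)C(=O)N1[C@@H]2C[C@@H]2C[C@H]1C(=O)NCc1cc(Cl)ccc1-n1cnnn1`). It differs from compound 2 by having butyl in place of phenyl on a saturated chain carbon bound to a carbonyl carbon and an oxygen on a saturated carbon. For the measured compounds named here, no measured pair shows this change, so the expectation rests on thin evidence. Both compound 1, at 1400 nM, and compound 2, at 680 nM, keep a phenyl that compound 3 lacks, and neither shows what losing it does. A moderate weakening in this assay seems the likeliest outcome, although a step within the scatter cannot be excluded. The expected change is a 2.2-fold higher number from compound 2 to compound 3 (0.34 log units; beyond the scatter). For compound 3 the estimated value is 1500 nM, with an expected range from 400 nM to 5000 nM.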

Compound 3, half-maximal inhibitory concentration: 870 nM
For compound 3 the middle estimate is 1.7-fold (0.24 log units) above the measured one; low and high end bracket the measured number.
By their numbers in this assay, from the lowest: compounds 2, 3 and 1 (each within the scatter of the next, the first and the last beyond it).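

In this assay, putting butyl in place of phenyl on a saturated chain carbon bound to a carbonyl carbon and an oxygen on a saturated carbon gives a 1.3-fold higher number from compound 2 to compound 3 (0.11 log units; within the scatter), so the two compounds cannot be told apart in this assay. For the compounds shown here, this is the first direct reading of this position, and it shows that one six-membered aromatic ring of carbon only is not needed there to keep a value in this range: an open butyl chain with no ring, and with fewer heavy atoms than phenyl, serves as well within the scatter. The data shown offer no measurement that could account for this result.

From the compounds shown here alone, with butyl as the only replacement for phenyl at this place, it remains open how a longer chain, a cyclohexyl ring, or a chain carrying an amine or a carboxylic acid would read there. Going by these compounds, it also remains open whether the same exchange would give a similarly small step on the core of compound 1, or in any setting other than this plasma assay.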